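The source may report more compounds than this note shows. Statements on the series, on what has been measured and on what is new or still open speak of the compounds shown alone.

Measured compounds:
Compound 1, `CCCOC(=O)CCC(=O)N1CCN(CCCOc2cc3c(Nc4ccc(F)c(Cl)c4)ncnc3cc2OC)CC1`, in a functional assay on A549 cells (Homo sapiens) for cytotoxicity, read by MTT assay, with a stated time of 24 h, tested at 10 uM; on this read-out lower numbers stand for a stronger effect and higher numbers for a weaker effect at the one concentration tested: 95.1%
Compound 2, `CCCCCCCOC(=O)CCC(=O)N1CCN(CCCOc2cc3c(Nc4ccc(F)c(Cl)c4)ncnc3cc2OC)CC1`, in this assay: 89.1%

Within the data shown here, compound 2 and compound 1 are the only two compounds measured so far, and the scatter does not separate them: the single measured step between them, a number 6 percentage points lower from compound 1 to compound 2 (within the scatter), came with a butyl in place of hydrogen on a saturated chain carbon, three bonds along the chain from an oxygen next to a carbonyl group.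

Compound 3, `CCCCCCCCCCCOC(=O)CCC(=O)N1CCN(CCCOc2cc3c(Nc4ccc(F)c(Cl)c4)ncnc3cc2OC)CC1`, has not yet been measured in this assay. It differs from compound 2 by butyl in place of hydrogen on a saturated chain carbon, seven bonds along the chain from an oxygen next to a carbonyl group. Among the measured compounds shown here, the one measured step that bears on this change is a number 6 percentage points lower from compound 1 to compound 2 (within the scatter), the same kind of chain lengthening cut earlier in the chain, and it stayed within the scatter. On that basis compound 3 is expected to show a number 4.1 percentage points lower from compound 2 to compound 3 (within the scatter), that is, no step beyond the scatter and at most a slight drift toward a lower number. The estimate for compound 3 in this assay is 85%, with a range from 70% to 98%.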

Compound 3, a percentage reported as activity, at one concentration (the size of the read-out at that concentration, not a potency): 93.4%
Compound 3: the middle estimate sits 8.4 percentage points below what was measured; the measured number falls inside the stated range.
By their numbers in this assay, from the lowest: compounds 2, 3 and 1 (each within the scatter of the next).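

In this assay, the butyl entering seven bonds along the chain from an oxygen next to a carbonyl group gave a number 4.3 percentage points higher from compound 2 to compound 3 (within the scatter), so a second lengthening, further out than the first, also stayed inside the scatter. Read over the whole span, octyl in place of hydrogen three bonds along the chain from that oxygen gave a number 1.7 percentage points lower from compound 1 to compound 3 (within the scatter), so even this larger change at the same chain leaves compound 1 and compound 3 unseparated, and the three compounds show no trend with chain length at the one concentration tested. No supporting information accompanies these numbers that could explain this flat result.

The compounds shown leave open whether any change at this end of the molecule can move the read-out beyond the scatter, since all three carry a plain saturated chain on the ester. What an amine or a carboxylic acid at the end of that chain would do, or a phenyl ring there, or a still longer chain, remains an open question.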